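Adding fluoro to the chloro-substituted styryl benzamide

The source may hold more compounds than are shown below. What is called first, only, known or untested is meant among the compounds shown, and "the series" means these compounds.

Measured values in a functional assay on HUVEC cells (Homo sapiens) for inhibition, with a stated time of 4 days (on this read-out higher numbers stand for weaker inhibition and lower numbers for stronger inhibition), for each compound
Compound 1 `COc1ccc(C(N)=O)cc1/C=C/c1ccc(Cl)cc1` gives 87 nM
Compound 2 `COc1ccc(C(N)=O)cc1/C=C\c1ccc(Cl)cc1` gives 2900 nM
Compound 3 `COc1ccc(C(N)=O)cc1/C=C/c1ccc(F)cc1` gives 2100 nM

Compound 1 has the lowest number of the three, and both of its measured steps lie beyond the scatter. Moving the double bond from E to Z gave a 33-fold higher number from compound 1 to compound 2 (1.52 log units; beyond the scatter) and this gap rests on configuration alone because of the fact that compounds 1 and 2 differ only in the configuration as drawn in this series. Fluoro in place of chloro gave a 24-fold higher number from compound 1 to compound 3 (1.38 log units; beyond the scatter) on the same core.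

The next change is fluoro in place of hydrogen on an aromatic carbon and yields compound 4 `COc1ccc(C(N)=O)cc1/C=C/c1ccc(Cl)cc1F` with the new fluoro ortho to a large group and meta to a chloro group. Neither measured step tests this replacement of hydrogen directly. Compound 4 keeps the chloro group whose loss gave a 24-fold higher number from compound 1 to compound 3 (1.38 log units; beyond the scatter) and also keeps the E double bond whose change gave a 33-fold higher number from compound 1 to compound 2 (1.52 log units; beyond the scatter) so a loss of either size is not expected. No step beyond the scatter is expected in this assay although a slight lean towards a higher number is allowed. The expected step is a 1.3-fold higher number from compound 1 to compound 4 (0.10 log units; within the scatter) on this estimate. Compound 4 is estimated at 110 nM with a range from 30 nM to 450 nM as the expected bounds.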

Compound 4, half-maximal inhibitory concentration: 1700 nM
Compound 4: middle estimate off by 15-fold (1.19 log units), on the low side, and the stated range ends below it.
By their numbers in this assay, from the lowest: compound 1; then compounds 4, 3 and 2 (each within the scatter of the next).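

In this assay, fluoro in place of hydrogen at this position, ortho to a large group and meta to a chloro group, gave a 20-fold higher number from compound 1 to compound 4 (1.29 log units; beyond the scatter) on the otherwise unchanged core of compound 1. The earlier steps shown here tied the low number of compound 1 to the chloro group and the E double bond, but compound 4 keeps both and still loses that low number, so these two features are not sufficient and this aromatic carbon is also sensitive to change. The data shown give no account of why this replacement of hydrogen has so large an effect, and the only supporting fact concerns configuration rather than this position.

The compounds shown leave open whether the step is particular to fluoro or follows any replacement of hydrogen here, which a methyl group, a hydroxyl group or an amine at the same carbon would help to separate. They also leave open whether fluoro on the other free carbons of this ring would give a number near that of compound 1 or near that of compound 4.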